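Bromo Substitution on the Naphthyl Analogue

The source may report more compounds than this note shows. Statements on the series, on what has been measured and on what is new or still open speak of the compounds shown alone.

Of the compounds shown here, two have been measured. Compound 1 `COc1ccc(C2=NN(C3=NC(=O)/C(=C4\C(=O)Nc5ccc(Br)cc54)S3)C(c3ccc(OC)cc3)C2)cc1` gives 32500 nM in a functional assay on cells (Cancer cell lines, Homo sapiens) for cytotoxicity, read by sulforhodamine B assay, with a stated time of 48 h (on this read-out lower numbers stand for stronger inhibition of growth and higher numbers for weaker inhibition of growth), and compound 2 `COc1ccc(C2CC(c3ccc4ccccc4c3)=NN2C2=NC(=O)/C(=C3\C(=O)Nc4ccccc43)S2)cc1` gives 24200 nM in this assay; the two numbers lie within the usual scatter of each other, so neither is separated from the other. Compound 3 `COc1ccc(C2CC(c3ccc4ccccc4c3)=NN2C2=NC(=O)/C(=C3\C(=O)Nc4ccc(Br)cc43)S2)cc1` differs from compound 2 by bromo in place of hydrogen on an aromatic carbon. Among the compounds with values here, no step between measured compounds is available for this change, and the pair compound 1 and compound 2 differs in two places. The step of a 1.0-fold higher number from compound 2 to compound 3 (0.01 log units; within the scatter) is therefore expected to stay within the scatter. Compound 3 is estimated at 25000 nM, with a range from 10000 nM to 60000 nM.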

Compound 3, concentration for total growth inhibition: 850 nM
Beside the measured number, compound 3's estimate is 29-fold (1.47 log units) above it, outside the stated range (below it).
By their numbers in this assay, from the lowest: compound 3; then compounds 2 and 1 (each within the scatter of the next).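

In this assay bromo in place of hydrogen on this aromatic carbon gives a 28-fold lower number from compound 2 to compound 3 (1.45 log units; beyond the scatter) and so shows that the position responds strongly to this change when naphthalen-2-yl is present. With bromo kept, naphthalen-2-yl in place of 4-methoxyphenyl gives a 38-fold lower number from compound 1 to compound 3 (1.58 log units; beyond the scatter) and compound 3 alone among those shown carries both groups. Nothing available bears on the cause of these steps. On these data alone, whether chloro, methyl or an amine on that carbon would give a similar step remains open. So does whether bromo has this effect with 4-methoxyphenyl in place of naphthalen-2-yl.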